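Working notes: aryl replacement from compound 2 to compound 3

The compounds below may be only part of what the source reports. "The series", "measured", "known", "first", "only" and "open" are said of these compounds alone.

Measured so far:
compound 1 `Brc1cn2ccnc2c(-c2ccc3ncn(C4CCCCC4)c3c2)n1` — 16.2%
compound 2 `CC(=O)c1ccc(-c2cn3ccnc3c(-c3ccc4ncn(C5CCCCC5)c4c3)n2)cc1` — 10.4%

Both numbers come from a functional assay on NCI-H522 cells (Homo sapiens) for inhibition, read by sulforhodamine B assay, with a stated time of 48 h, tested at 10 uM; on this read-out higher numbers stand for more inhibition at the one concentration tested (going by the name of the read-out) and lower numbers for less inhibition. Within the data shown here, compound 2 gives 10.4% and stands at the lower of the two values; the only neighbour is compound 1, and the step of a number 5.8 percentage points lower from compound 1 to compound 2 (within the scatter) lies within the scatter, so the two cannot be ranked against each other.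

Compound 3 `Fc1ccccc1-c1cn2ccnc2c(-c2ccc3ncn(C4CCCCC4)c3c2)n1` is not yet measured. It differs from compound 2 by 2-fluorophenyl in place of 4-acetylphenyl on an aromatic carbon. Among the measured compounds shown here, no measured step exchanges one aryl group for another at this position; the only measured step, a number 5.8 percentage points lower from compound 1 to compound 2 (within the scatter), puts an aryl group where a bromo atom stood and is itself within the scatter. That step is the nearest guide, and it gives no reason to expect a shift beyond the scatter in this assay in either direction.

Compound 3 is therefore estimated at 13%, with a range from 0% to 30%; the expected step is a number 2.6 percentage points higher from compound 2 to compound 3 (within the scatter), which is within the scatter.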

Compound 3, a percentage reported as inhibition, at one concentration (the size of the read-out at that concentration, not a potency): 17.8%
For compound 3 the middle estimate is 4.8 percentage points below the measured one, within the range that was stated.
By their numbers in this assay, from the lowest: compounds 2, 1 and 3 (each within the scatter of the next).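

In this assay, among these compounds, replacing one aryl group with another on this aromatic carbon next to the ring nitrogen gives a number 7.4 percentage points higher from compound 2 to compound 3 (within the scatter), the first aryl-for-aryl step. Swapping bromo for 2-fluorophenyl gives a number 1.6 percentage points higher from compound 1 to compound 3 (within the scatter), so with the two earlier compounds, bromo, 4-acetylphenyl and 2-fluorophenyl at this one position cannot be ranked against one another, and neither the presence of the acetyl carbonyl nor the change from a 4-substituted to a 2-substituted phenyl separates the values here. No measurement at hand bears on a cause for this lack of separation.

Still open, on these data alone, is whether any group at this position moves the number beyond the scatter, for instance an amine such as piperazine, a carboxylic acid on the phenyl ring, or a longer alkyl chain in place of the aryl group. Also open is whether a change to the cyclohexyl group on the other side of the shared core would do so, and how any of these compounds would behave at other concentrations or in other cell lines.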